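Benzyl in Place of the Amide on the Ring Nitrogen

A few compounds are considered here, and "the series" means these few. Any claim that something is new, unique, unknown or untested is made for them only; others in the source may bear on it.

Measured so far in an assay on isolated protein for binding affinity to secreted frizzled-related protein 1 (Homo sapiens), read by fluorescence; a higher number here means a weaker inhibitor, a lower number a stronger inhibitor:
compound 1 `CN(C)CC(=O)N1CCC(NS(=O)(=O)c2cc(S(=O)(=O)c3ccccc3)ccc2C(F)(F)F)CC1` gives 300 nM
compound 2 `CC(C)(C)OC(=O)N1CCC[C@H]1C(=O)N1CCC(NS(=O)(=O)c2cc(S(=O)(=O)c3ccccc3)ccc2C(F)(F)F)CC1` gives 60 nM
compound 3 `CC(C)(C)CC(=O)N1CCC[C@H]1C(=O)N1CCC(NS(=O)(=O)c2cc(S(=O)(=O)c3ccccc3)ccc2C(F)(F)F)CC1` gives 20 nM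

Compound 3 stands lowest of the three, ahead of compound 2 by a 3.0-fold lower number from compound 2 to compound 3 (0.48 log units; beyond the scatter) and of compound 1 by a 15-fold lower number from compound 1 to compound 3 (1.18 log units; beyond the scatter). Compound 4 `O=C([C@@H]1CCCN1Cc1ccccc1)N1CCC(NS(=O)(=O)c2cc(S(=O)(=O)c3ccccc3)ccc2C(F)(F)F)CC1` differs from compound 3 in one place: benzyl in place of neopentylcarbonyl on an amine nitrogen in a ring. Among the measured compounds shown here, no measured pair mirrors this swap; the steps that bear on it are a 5.0-fold lower number from compound 1 to compound 2 (0.70 log units; beyond the scatter), a 15-fold lower number from compound 1 to compound 3 (1.18 log units; beyond the scatter) and a 3.0-fold lower number from compound 2 to compound 3 (0.48 log units; beyond the scatter), which show that what sits on that amine nitrogen in a ring moves the number by modest to large amounts. The change keeps a group of similar size but removes the hydrogen-bond acceptor counted in the leaving group, so a modest rise is expected. Compound 4 is estimated at 50 nM (range 15 nM to 160 nM), a step of a 2.5-fold higher number from compound 3 to compound 4 (0.40 log units; beyond the scatter).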

Compound 4, half-maximal inhibitory concentration: 1400 nM
The estimate for compound 4 lay 28-fold (1.45 log units) below the measured number; the measured number lies above the stated range.
By their numbers in this assay, from the lowest: compound 3; then compound 2; then compound 1; then compound 4.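

Matching heavy-atom counts did not keep the number: benzyl for neopentylcarbonyl on the amine nitrogen in a ring gives a 70-fold higher number from compound 3 to compound 4 (1.85 log units; beyond the scatter). Benzyl for tert-butoxycarbonyl at the same nitrogen also costs heavily, with a 23-fold higher number from compound 2 to compound 4 (1.37 log units; beyond the scatter), so both groups bearing a carbonyl there outperform benzyl. The 1-benzylpyrrolidin-2-yl group even loses to (dimethylamino)methyl, with a 4.7-fold higher number from compound 1 to compound 4 (0.67 log units; beyond the scatter), so the ring alone does not secure the lower numbers of compound 2 and compound 3.

Nothing available explains this loss. A plain neopentyl or a benzoyl group on that nitrogen would separate the part played by the carbonyl from that of the phenyl ring.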